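One more fluoro on compound 2

A few compounds are considered here, and "the series" means these few. Any claim that something is new, unique, unknown or untested is made for them only; others in the source may bear on it.

Measured in a functional assay on MIA PaCa-2 cells (Homo sapiens) for cytotoxicity, read by MTT assay, with a stated time of 4 h; on this read-out higher numbers stand for weaker inhibition and lower numbers for stronger inhibition:
- compound 1 `COC1=CC(=O)c2c(COc3ccc(N)cc3)c(C)n(C)c2C1=O`: 504 nM
- compound 2 `COC1=CC(=O)c2c(COc3ccc(F)cc3F)c(C)n(C)c2C1=O`: 255 nM

Compound 2 stands at 255 nM in this assay. Among the measured compounds shown here, the only comparison available is a 2.0-fold lower number from compound 1 to compound 2 (0.30 log units; within the scatter), so the two compounds cannot be ranked on these numbers.

Compound 3 `COC1=CC(=O)c2c(COc3c(F)cc(F)cc3F)c(C)n(C)c2C1=O` is the next compound to be measured. The change is fluoro in place of hydrogen on an aromatic carbon, ortho to a large group and meta to two fluoro groups.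

For the measured compounds named here, only one measured step bears on this change, and it bears only loosely. a 2.0-fold lower number from compound 1 to compound 2 (0.30 log units; within the scatter) is a replacement of one substituted phenyl group by another, not the addition of a single fluoro, and it stays within the scatter. Going by the values given here, no measured step shows what a single added fluoro does. On that thin evidence, no step beyond the scatter is expected in this assay, and no direction is favoured. The expected step is a 1.1-fold lower number from compound 2 to compound 3 (0.03 log units; within the scatter). For compound 3 the estimated value is 240 nM, with an expected range of 100 nM to 550 nM.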

Compound 3, half-maximal inhibitory concentration: 452 nM
Beside the measured number, compound 3's estimate is 1.9-fold (0.27 log units) below it; measured number inside the range.
By their numbers in this assay, from the lowest: compounds 2, 3 and 1 (each within the scatter of the next).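

In this assay, among the compounds shown here, the added fluoro, on an aromatic carbon ortho to a large group and meta to two fluoro groups, gives a 1.8-fold higher number from compound 2 to compound 3 (0.25 log units; within the scatter) and is the first change limited to a single atom. The earlier step swapped one whole substituted phenyl group for another, whereas this one isolates a single ring carbon and shows that fluoro in place of hydrogen at this place does not separate compound 3 from compound 2 on this read-out. No measurement available here accounts for the size or direction of this step.

Still open, as far as these compounds go, is whether a chloro, methyl or methoxy group on the same aromatic carbon, or a larger group such as an amine or a carboxylic acid, would give a step beyond the scatter. Also open, from the compounds shown here alone, is whether a single fluoro at this place gives a similar step on a phenyl ring without the two other fluoro groups, since the present step was read only with both of them in place.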